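Carboxy in place of (dimethylamino)methyl on the chain

The source may hold more compounds than are shown below. What is called first, only, known or untested is meant among the compounds shown, and "the series" means these compounds.

The measurement followed here is an ADME assay for pharmacokinetics, read by LC-MS, in phosphate buffer, with a stated time of 120 min, at pH 7.4, tested at 1 uM, in the presence of a further agent that is not named here (a higher number here means that the compound lasts longer, a lower number that the compound disappears faster), and it has given three results so far. In this assay, going by the values given here, compound 2 (`CN(C)CC/C=C/C(=O)Nc1ccccc1`) gives 7.38 h as the only true number among them. Compound 1 (`CN1CCN(C/C=C/C(=O)Nc2ccccc2)CC1`) gives only a limit, > 8.53 h and no number. Compound 3 (`C=C(CCO)C(=O)Nc1ccccc1`) also gives only a limit, > 8.53 h and no number. Among the compounds with values here, what the set shows is the limit of > 8.53 h in this assay, at which 2 of the 3 values shown sit, and no compound that disappears fast.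

Compound 4 (`O=C(O)C/C=C/C(=O)Nc1ccccc1`) has not been measured yet. It differs from compound 2 by a single change: carboxy in place of (dimethylamino)methyl on a saturated chain carbon bound to a double-bonded chain carbon and in words carboxy in place of (dimethylamino)methyl on a saturated chain carbon bound to a double-bonded chain carbon.

Within the data shown here, no measured pair shows a swap of this kind, so there is no direct guide to its size. The expectation leans on compound 2 with its 7.38 h as a starting point, and on the absence of any short half-life among the measured compounds. Expected here is a 1.1-fold higher number from compound 2 to compound 4 (0.04 log units; within the scatter) and so no shift beyond the usual scatter in either direction. Compound 4 may well return only a limit too. For compound 4 the expected half-life is 8 h within an estimated range from 4 h to 16 h in a numerical reading.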

Compound 4, half-life: > 8.53 h
Compound 4: only a limit was reported; the forecaster's own chance of this, stated with the estimate: 55%; middle value at least 1.0-fold (0.02 log units) from the limit.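

Putting carboxy in place of (dimethylamino)methyl, on a saturated chain carbon bound to a double-bonded chain carbon, gives in this assay an at least 1.1-fold higher number from compound 2 to compound 4 (0.06 log units; that floor lies within the scatter). Going by these compounds, the result for compound 4, > 8.53 h, is a limit and not a number, so this step has a floor but no upper end, and its true size stays unknown. Going by these compounds alone, this is the first change at this position that can be read, and it gives no sign of a compound disappearing faster, whether the chain carries the amine of compound 2 or the carboxy of compound 4: the limit of > 8.53 h in this assay, at which 3 of the 4 values shown sit.

The compounds shown leave open how far compound 4 really lies past its limit, and whether any group at this place can shorten the half-life at all. A methyl ester in place of the carboxy, or a longer chain carrying the carboxy, would probe the same position, but the size of such a change could be read only if the compounds gave true numbers rather than limits.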